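A few compounds are considered here, and "the series" means these few. Any claim that something is new, unique, unknown or untested is made for them only; others in the source may bear on it.

Measured in a functional assay on RAW264.7 cells (Mus musculus) for inhibition, read by Griess assay, with stated times of 1 h and 24 h; a higher number here means a weaker inhibitor, a lower number a stronger inhibitor:
- compound 1 `CCCCCCOc1ccc(C(O)C2OC(=O)c3c(OC)cc(OC)cc32)cc1`: 5360 nM
- compound 2 `COCCCCOc1ccc(C(O)C2OC(=O)c3c(OC)cc(OC)cc32)cc1`: 8210 nM
- compound 3 `CCOCCOc1ccc(C(O)C2OC(=O)c3c(OC)cc(OC)cc32)cc1`: > 10000 nM (a limit, not a number)

Compound 3 sits at the limit of > 10000 nM in this assay, at which 1 of the 3 values shown sits, so it has no exact value of its own. The unmeasured compound 4 `C=CCCOc1ccc(C(O)C2OC(=O)c3c(OC)cc(OC)cc32)cc1` shares its core and differs only at the end of the chain: vinyl in place of ethoxy on a saturated chain carbon, two bonds along the chain from an oxygen on an aromatic ring. In words, this is vinyl in place of ethoxy on a saturated chain carbon, two bonds along the chain from an oxygen on an aromatic ring, which turns 2-ethoxyethoxy into (but-3-en-1-yl)oxy.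

Three measured steps change this same chain. The closest is an at least 1.8-fold higher number from compound 1 to compound 3 (0.27 log units; that floor lies within the scatter), where ethoxy enters in place of butyl. The second is an at least 1.2-fold higher number from compound 2 to compound 3 (0.08 log units; that floor lies within the scatter), and the third is a 1.5-fold higher number from compound 1 to compound 2 (0.19 log units; within the scatter). None of the three is shown to go beyond the scatter, so they give no firm size for a change in this chain. All three measured compounds fall close together, and compound 4 is expected to join them. The expected change is an at least 1.2-fold lower number from compound 3 to compound 4 (0.09 log units; that floor lies within the scatter), which would be no larger than the scatter and, if anything, towards a lower number. For compound 4 the estimated value is 8000 nM, with an expected range of 4000 nM to 14000 nM.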

Compound 4, half-maximal inhibitory concentration: 1330 nM
Beside the measured number, compound 4's estimate is 6.0-fold (0.78 log units) above it, outside the stated range (below it).
By their numbers in this assay, from the lowest: compound 4; then compounds 1 and 2 (each within the scatter of the next). At a limit, above all of these: compound 3.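

In this assay, for the compounds shown here, the (but-3-en-1-yl)oxy chain gives the first steps at this position that lie beyond the scatter: a 6.2-fold lower number from compound 2 to compound 4 (0.79 log units; beyond the scatter) and a 4.0-fold lower number from compound 1 to compound 4 (0.61 log units; beyond the scatter). Losing the ether oxygen of the chain does not account for this alone, as compound 1, with butyl at this place and likewise without that oxygen, still stands above compound 4 by the second of those steps. The value of compound 3 is a limit and not a number, so its step, an at least 7.5-fold lower number from compound 3 to compound 4 (0.87 log units; beyond the scatter), gives only a floor for replacing ethoxy with vinyl: the limit of > 10000 nM in this assay, at which 1 of the 4 values shown sits.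

The compounds shown leave open whether the gain belongs to the double bond itself or to the shorter chain, as compound 4 differs from compound 1 in both; a saturated butoxy chain would separate the two. A but-3-yn-1-yl chain, ending in a triple bond, would show whether a double bond is specifically needed at the end of the chain or whether another unsaturated end serves as well.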